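The compounds below may be only part of what the source reports. "The series", "measured", "known", "first", "only" and "open" are said of these compounds alone.

Measured in an ADME assay on Huh-7 cells (Homo sapiens) for cytotoxicity, with a stated time of 72 h; on this read-out higher numbers stand for lower toxicity in this test and lower numbers for higher toxicity in this test:
- compound 1 `CC(C)CCn1nc(-c2cccs2)c(O)c(C2=NS(=O)(=O)c3cc(S(=O)(=O)N(C)C)ccc3N2)c1=O`: "not determined" (no result reported)
- compound 2 `CC(C)CCn1nc(C2CCC2)c(O)c(C2=NS(=O)(=O)c3cc(NS(C)(=O)=O)ccc3N2)c1=O`: > 33000 nM

Compound 1 has no result in this assay, so it offers no comparison. Compound 2 stands at > 33000 nM, which is a limit of the assay and not a number. Within the data shown here, the series therefore has no single measured value so far, and no measured pair shows what a change in one place does.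

Compound 3 `CC(C)CCn1nc(CC(C)C)c(O)c(C2=NS(=O)(=O)c3cc(NS(C)(=O)=O)ccc3N2)c1=O` keeps the rest of compound 2 but carries isobutyl in place of cyclobutyl on an aromatic carbon, next to the ring nitrogen and ortho to a hydroxy group: isobutyl in place of cyclobutyl on an aromatic carbon. The swap leaves the number of heavy atoms unchanged and opens the four-membered ring.

No step beyond the scatter is expected in this assay, in either direction. This expectation rests only on compound 2, whose limit is > 33000 nM. The expected change is a step that the limit leaves unreadable from compound 2 to compound 3. A report of compound 3 as a limit alone is thought to be the likeliest outcome. If a number is obtained, compound 3 is expected at 35000 nM, with an estimated range of 15000 nM to 70000 nM.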

Compound 3, half-maximal cytotoxic concentration: > 1000 nM
Compound 3: a limit, no number; the forecaster's own chance of this, stated with the estimate: 70%; the middle value does not contradict the limit.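

In this assay compound 3 gives > 1000 nM, which is a limit and not a number, and since compound 2 also stands at a limit, no step can be read between compound 2 and compound 3. The compounds shown leave open whether isobutyl in place of cyclobutyl changes the half-maximal cytotoxic concentration at all.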